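The source may hold more compounds than are shown below. What is called first, only, known or untested is meant among the compounds shown, and "the series" means these compounds.

Compounds measured so far

- compound 1: `Fc1ccc(-c2cn3ccnc3c(-c3ccc4ncn(C5CCCCC5)c4c3)n2)cc1` — 10.7%
- compound 2: `CCc1ccc(-c2cn3ccnc3c(-c3ccc4ncn(Cc5ccccc5)c4c3)n2)cc1` — 30.5%

Both were tested in a functional assay on SF-268 cells (Homo sapiens) for inhibition, read by sulforhodamine B assay, with a stated time of 48 h, tested at 10 uM; on this read-out higher numbers stand for more inhibition at the one concentration tested (going by the name of the read-out) and lower numbers for less inhibition. Compound 2 stands highest of the two numbers; its nearest neighbour is compound 1, which gives 10.7%, a difference beyond the usual scatter. Going by the values given here, compound 1 and compound 2 differ in two places, so no single step between them can be read off, and the two values say only that compound 2 inhibits more under these conditions.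

The next compound to be measured is compound 3, `Cc1cccc(-c2cn3ccnc3c(-c3ccc4ncn(Cc5ccccc5)c4c3)n2)c1`. It is a single-point change from compound 2: 3-methylphenyl in place of 4-ethylphenyl on an aromatic carbon. The 4-ethylphenyl is replaced by a 3-methylphenyl on the same aromatic carbon, a shorter alkyl group in a different ring position.

Among the compounds with values here, there is no measured pair in this small set that isolates a change of this kind, so the direction of the step is uncertain. Within the data shown here, with only two measured compounds, the step is expected to be small, a number 8.5 percentage points lower from compound 2 to compound 3 (within the scatter), likely within or close to the scatter, and downward rather than upward if anything. Compound 3 is therefore expected to give 22% in this assay, with a range from 5% to 40%.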

Compound 3, a percentage reported as inhibition, at one concentration (the size of the read-out at that concentration, not a potency): 7.22%
Compound 3: middle estimate off by 14.8 percentage points, on the high side, within the range that was stated.
By their numbers in this assay, from the lowest: compounds 3 and 1 (each within the scatter of the next); then compound 2.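

This position on the shared core now has its first readable single change: in this assay, 3-methylphenyl in place of 4-ethylphenyl gives a number 23.3 percentage points lower from compound 2 to compound 3 (beyond the scatter). Inhibition at the one concentration tested therefore responds to the aryl group on this aromatic carbon, even though both groups carry one six-membered aromatic ring of carbon only and neither has hydrogen-bond donors or acceptors. The change alters the alkyl group and its ring position together, and nothing available explains the lower number.

Which of those two differences matters, the shorter alkyl group or its new ring position, stays open, and a phenyl without any alkyl group or a longer chain such as propyl on this ring would bear on that question. Also open, as far as these compounds go, is how an amine or a carboxylic acid on this ring would read in this assay, and whether the step holds with a group other than benzyl on the far side of the core.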